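Replacing nitro with trifluoromethyl: notes on compound 4

A few compounds are considered here, and "the series" means these few. Any claim that something is new, unique, unknown or untested is made for them only; others in the source may bear on it.

Compound 1 `COc1cc(O)c(CC=C(C)C)c(O)c1C(=O)/C=C/c1ccc(C(F)(F)F)cc1` gives 6500 nM
Compound 2 `COc1ccc(/C=C/C(=O)c2c(O)cc(O)cc2OC)cc1` gives 18100 nM
Compound 3 `COc1cc(O)cc(O)c1C(=O)/C=C/c1ccc([N+](=O)[O-])cc1` gives 41000 nM

All three values come from a functional assay on HepG2 cells (Homo sapiens) for inhibition, read by MTT assay, with a stated time of 72 h (on this read-out higher numbers stand for weaker inhibition and lower numbers for stronger inhibition), and compound 3 has the highest number of the three, with compound 2 nearest and compound 1 furthest. Compound 4 `COc1cc(O)cc(O)c1C(=O)/C=C/c1ccc(C(F)(F)F)cc1` carries trifluoromethyl in place of nitro on an aromatic carbon, para to a large group (trifluoromethyl in place of nitro on an aromatic carbon), and is otherwise the same as compound 3. Going by the values given here, one measured step bears directly on this place (a 2.3-fold higher number from compound 2 to compound 3 (0.36 log units; beyond the scatter)). There, nitro in place of methoxy was a modest change, beyond the scatter. Compound 1 also carries trifluoromethyl and gives the lowest number (6500 nM), but it differs elsewhere in the core and is only a loose guide. A modest step towards a lower number is therefore expected in this assay, of similar size to the one measured. The estimated step is a modest one (a 2.1-fold lower number from compound 3 to compound 4 (0.31 log units; beyond the scatter)). In this assay compound 4 is expected at 20000 nM (estimated range 8000 nM to 45000 nM).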

Compound 4, half-maximal inhibitory concentration: 14100 nM
Compound 4: middle estimate off by 1.4-fold (0.15 log units), on the high side; the range from low to high includes it.
By their numbers in this assay, from the lowest: compound 1; then compounds 4 and 2 (each within the scatter of the next); then compound 3.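

In this assay this place now has a direct comparison of trifluoromethyl with nitro, with a 2.9-fold lower number from compound 3 to compound 4 (0.46 log units; beyond the scatter) on the shared core. Trifluoromethyl and methoxy at this place cannot be told apart, with a 1.3-fold lower number from compound 2 to compound 4 (0.11 log units; within the scatter), while nitro stands apart from both with the highest number of the three. With trifluoromethyl held fixed, hydrogen in place of 3-methylbut-2-en-1-yl on an aromatic carbon turns the loose link to compound 1 into a measured step, with a 2.2-fold higher number from compound 1 to compound 4 (0.34 log units; beyond the scatter) in this series.

Nothing measured here gives a reason for these steps.

Still open, from the compounds shown here alone, is whether an amine, a carboxylic acid or a longer chain at this place would separate from trifluoromethyl and methoxy, and whether 3-methylbut-2-en-1-yl gives a similar step alongside nitro or methoxy.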